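The compounds below may be only part of what the source reports. "The series", "measured", "known", "first", "only" and "open" are said of these compounds alone.

Measured so far in a functional assay on A549 cells (Homo sapiens) for antiproliferative activity, read by MTT assay, with a stated time of 48 h; a higher number here means a weaker inhibitor, a lower number a stronger inhibitor (lower numbers mean stronger inhibition):

- Compound 1 (`Cc1ccc2nc(NC(c3cn(-c4ccccc4)nc3-c3cccc(Cl)c3)c3c(O)ccc4ccccc34)sc2c1`) gives 45400 nM
- Compound 2 (`COc1cccc(-c2nn(-c3ccccc3)cc2C(Nc2nc3ccccc3s2)c2c(O)ccc3ccccc23)c1`) gives 24800 nM
- Compound 3 (`Cc1cccc(-c2nn(-c3ccccc3)cc2C(Nc2nc3ccccc3s2)c2c(O)ccc3ccccc23)c1`) gives 18500 nM

Compound 3 stands level with compound 2 within the scatter, while compound 1 shows a higher number, beyond the scatter. The next compound, compound 4 (`Oc1ccc2ccccc2c1C(Nc1nc2ccccc2s1)c1cn(-c2ccccc2)nc1-c1cccc(Cl)c1`), has chloro in place of methyl on an aromatic carbon, meta to a large group, so that 3-methylphenyl becomes 3-chlorophenyl (chloro in place of methyl on an aromatic carbon). Among the compounds with values here, only one measured step touches this place: a 1.3-fold lower number from compound 2 to compound 3 (0.13 log units; within the scatter), with methyl in place of methoxy, and it stayed within the scatter. That step did not involve chloro, however. Compound 1 also carries 3-chlorophenyl and gives 45400 nM, so the range is left wider on the upper side. No step beyond the scatter is therefore expected in this assay, and the expected step is a 1.3-fold higher number from compound 3 to compound 4 (0.11 log units; within the scatter). For compound 4 the estimated value is 24000 nM, with an expected range of 11000 nM to 55000 nM.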

Compound 4, half-maximal inhibitory concentration: 20400 nM
For compound 4 the middle estimate is 1.2-fold (0.07 log units) above the measured one; the range from low to high includes it.
By their numbers in this assay, from the lowest: compounds 3, 4, 2 and 1 (each within the scatter of the next, the first and the last beyond it).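

In this assay, chloro in place of methyl at this place gives a 1.1-fold higher number from compound 3 to compound 4 (0.04 log units; within the scatter), and chloro in place of methoxy gives a 1.2-fold lower number from compound 2 to compound 4 (0.08 log units; within the scatter), so methyl, methoxy and chloro on this aromatic carbon now all stand within the scatter of one another. Within the data shown here, the only step beyond the scatter lies at another place: with 3-chlorophenyl held constant, loss of a methyl from the core gives a 2.2-fold lower number from compound 1 to compound 4 (0.35 log units; beyond the scatter), a modest step. Nothing measured here accounts for either result.

From the compounds shown here alone, whether an amine or a carboxylic acid at this place would also stay within the scatter remains open. Going by these compounds, it is also open whether the methyl step seen between compound 1 and compound 4 would recur with 3-methylphenyl in place of 3-chlorophenyl.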